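Aryl urea series: ester in place of trifluoromethyl

This account rests on a few compounds, and the source may have more. Where it says the series, first, only, none or still open, it means among the compounds named here.

Values in an ADME assay on the whole organism with Oryza sativa as the target, tested at 1 uM; a lower number here means a stronger effect, a higher number a weaker effect of the compound at the concentration tested:
compound 1 `CCc1cccc(NC(=O)N[C@@H](C)c2ccccc2)c1`: 94%
compound 2 `CC(C)c1cccc(NC(=O)N[C@@H](C)c2ccccc2)c1`: 84%
compound 3 `C[C@H](NC(=O)Nc1cccc(C(F)(F)F)c1)c1ccccc1`: 93%

Compound 3 stands second highest of the three, nearest compound 1 (a number 1 percentage points lower from compound 1 to compound 3 (within the scatter)) and furthest from compound 2 (a number 9 percentage points higher from compound 2 to compound 3 (within the scatter)); all three values sit within the scatter of one another.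

Compound 4 `CCOC(=O)c1cccc(NC(=O)N[C@@H](C)c2ccccc2)c1` differs from compound 3 by ethoxycarbonyl in place of trifluoromethyl on an aromatic carbon. The two steps that bear on this are the swaps at the same aromatic carbon, a number 1 percentage points lower from compound 1 to compound 3 (within the scatter) and a number 9 percentage points higher from compound 2 to compound 3 (within the scatter), both within the scatter, as is a number 10 percentage points lower from compound 1 to compound 2 (within the scatter) on the saturated chain. No step beyond the scatter is therefore expected from compound 3 to compound 4 in this assay. The expected step is a number 3 percentage points lower from compound 3 to compound 4 (within the scatter). Compound 4 is estimated at 90%, range 78% to 98%.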

Compound 4, a percentage reported as activity, at one concentration (the size of the read-out at that concentration, not a potency): 99%
For compound 4 the middle estimate is 9 percentage points below the measured one; measured number outside the range, above it.
By their numbers in this assay, from the lowest: compounds 2, 3, 1 and 4 (each within the scatter of the next, the first and the last beyond it).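

In this assay, going by these compounds alone, ethoxycarbonyl on this aromatic carbon gives the first step beyond the scatter (a number 15 percentage points higher from compound 2 to compound 4 (beyond the scatter)), and it is a modest one, seen only against isopropyl. Against the other two groups the swap stays within the scatter (a number 6 percentage points higher from compound 3 to compound 4 (within the scatter); a number 5 percentage points higher from compound 1 to compound 4 (within the scatter)). Hydrogen-bond acceptors on this carbon therefore bring no lower number than ethyl or trifluoromethyl give.

On these data alone, whether a carboxylic acid or an amine here would move the number beyond the scatter remains open. Nothing at hand speaks to the cause of these steps.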